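The source may hold more compounds than are shown below. What is called first, only, known or untested is meant among the compounds shown, and "the series" means these compounds.

Measured in an assay on isolated protein for inhibition of Dihydrofolate reductase (Homo sapiens), read by spectrophotometry, using NADPH, with a stated time of 10 min; a higher number here means a weaker inhibitor, a lower number a stronger inhibitor:
Compound 1, `Cc1cc2nc(-c3ccco3)n(-c3ccc4c(N)nc(N)nc4c3)c2cc1C`, gives 943 nM.
Compound 2, `Cc1cc2nc(-c3cccn3C)n(-c3ccc4c(N)nc(N)nc4c3)c2cc1C`, gives only a limit of the assay, > 5000 nM.
Compound 3, `Cc1cc2nc(-c3ccncc3)n(-c3ccc4c(N)nc(N)nc4c3)c2cc1C`, gives 437 nM.

Among these, compound 3 has the lowest number, with compound 1 nearest, as a 2.2-fold lower number from compound 1 to compound 3 (0.33 log units; beyond the scatter) shows; against compound 2 the step of an at least 11-fold lower number from compound 2 to compound 3 (1.05 log units; beyond the scatter) is at least large. Compound 4, `Cc1cc2nc(C3CC3)n(-c3ccc4c(N)nc(N)nc4c3)c2cc1C`, differs from compound 3 in one place: cyclopropyl in place of pyridin-4-yl on an aromatic carbon. Among the measured compounds shown here, no measured step swaps an aromatic ring for a non-aromatic one; the steps that bear on this position, an at least 5.3-fold higher number from compound 1 to compound 2 (0.72 log units; beyond the scatter) and a 2.2-fold lower number from compound 1 to compound 3 (0.33 log units; beyond the scatter), exchange one aromatic ring for another, and both lie beyond the scatter. A step toward a higher number in this assay is therefore expected for compound 4, of the size a 3.4-fold higher number from compound 3 to compound 4 (0.54 log units; beyond the scatter). Compound 4 is estimated at 1500 nM, between 400 nM and 6000 nM.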

Compound 4, inhibition constant: 1160 nM
The estimate for compound 4 lay 1.3-fold (0.11 log units) above the measured number; the range from low to high includes it.
By their numbers in this assay, from the lowest: compound 3; then compounds 1 and 4 (each within the scatter of the next). At a limit, above all of these: compound 2.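

Here a non-aromatic ring appears at this position for the first time, and cyclopropyl holds up: the step of a 1.2-fold higher number from compound 1 to compound 4 (0.09 log units; within the scatter) shows no real change from furan-2-yl. Pyridin-4-yl still gives the lower number, with a 2.7-fold higher number from compound 3 to compound 4 (0.42 log units; beyond the scatter) as the step away from it. Set against a limit of the assay, an at least 4.3-fold lower number from compound 2 to compound 4 (0.63 log units; beyond the scatter) is a bound only and not an exact step.

Nothing measured here accounts for these steps. From the compounds shown here alone, whether an open chain such as propyl, or an amine, would serve at this place stays open.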